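Compound 2 to compound 4: cytotoxicity from a limit

The source may hold more compounds than are shown below. What is called first, only, known or untested is meant among the compounds shown, and "the series" means these compounds.

- Compound 1 `COc1ccc(-c2nc3cc(C(C)O)ccc3[nH]2)c(OC)c1` reads > 100000 nM (a limit)
- Compound 2 `COc1ccc(-c2nc3cc(/C(C)=N/O)ccc3[nH]2)c(OC)c1` reads > 100000 nM (a limit)
- Compound 3 `COc1ccc(-c2nc3cc(/C(C)=N/O)ccc3[nH]2)c(OC)c1OC` reads > 100000 nM (a limit)

All of these readings come from an ADME assay on Vero cells (Chlorocebus sabaeus) for cytotoxicity, read by MTT assay, with a stated time of 96 h (on this read-out lower numbers stand for higher toxicity in this test and higher numbers for lower toxicity in this test), and none of them is a number. The whole set shares one reading: the limit of > 100000 nM in this assay, at which 3 of the 3 values shown sit. Compound 2 therefore stands at a limit and has no measured position of its own.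

The next structure is compound 4 `COc1ccc(-c2nc3cc(/C(C)=N/NC(N)=S)ccc3[nH]2)c(OC)c1`, and the change that leads to it is a group of 4 heavy atoms (1 carbon, 2 nitrogen, 1 sulfur; no ring) in place of one oxygen atom, on a double-bonded nitrogen. The measured changes nearest to it are a step that the two limits leave unreadable from compound 1 to compound 2 and a step that the two limits leave unreadable from compound 2 to compound 3. Among the measured compounds shown here, neither gives a size to carry over, and no measured compound holds the entering group.

Compound 2 sits at > 100000 nM, a limit, so a readable result can only lie lower, towards higher toxicity in this test. A limit reading is also quite possible. The expected change is an at least 2.5-fold lower number from compound 2 to compound 4 (0.39 log units; beyond the scatter), an estimate with little support. For compound 4 the estimated value is 40000 nM, with an expected range from 8000 nM to 100000 nM.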

Compound 4, half-maximal cytotoxic concentration: > 100000 nM
Compound 4 was reported as a limit (the forecaster's own chance of this, stated with the estimate: 45%); middle value at least 2.5-fold (0.39 log units) from the limit.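

Compound 4 reads > 100000 nM in this assay, and this is a limit. Among the compounds shown here, no new step can therefore be read from compound 4 to compound 1 or compound 2. The compounds shown leave open how large any of these steps is: the limit of > 100000 nM in this assay, at which 4 of the 4 values shown sit.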